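A swap on the carbonyl of compound 2

The source may hold more compounds than are shown below. What is called first, only, known or untested is meant among the compounds shown, and "the series" means these compounds.

In an ADME assay on MT4 cells (Homo sapiens) for cytotoxicity, read by MTT assay (on this read-out higher numbers stand for lower toxicity in this test and lower numbers for higher toxicity in this test), compound 1 (`O=C(CSc1nncnc1-c1cccc2ccccc12)Nc1ccccc1[N+](=O)[O-]`) gives 142000 nM and compound 3 (`COC(=O)c1ccc(NC(=O)CSc2nncnc2-c2cccc3ccccc23)c(Br)c1`) gives 173000 nM. Compound 2 (`O=C(CSc1nncnc1-c1ccccc1Cl)c1ccc(Cl)c(Cl)c1`) gives 33000 nM, the lowest of the three numbers and so the most toxic result among them. Compound 4 (`O=C(CSc1nncnc1-c1ccccc1Cl)Nc1ccccc1Br`) has not been measured yet. It carries (2-bromophenyl)amino in place of 3,4-dichlorophenyl on a carbonyl carbon, ((2-bromophenyl)amino in place of 3,4-dichlorophenyl on a carbonyl carbon). Among the measured compounds shown here, no measured pair shows this change alone. Compound 1 at 142000 nM and compound 3 at 173000 nM also have an amino-linked ring on the carbonyl, although their cores differ from that of compound 2. In this assay, an upward step beyond the scatter is therefore expected, a 3.0-fold higher number from compound 2 to compound 4 (0.48 log units; beyond the scatter). The estimate for compound 4 is 100000 nM, within an expected range of 35000 nM to 280000 nM.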

Compound 4, half-maximal cytotoxic concentration: 73000 nM
Estimate against measurement, compound 4: 1.4-fold (0.14 log units) above, within the range that was stated.
By their numbers in this assay, from the lowest: compound 2; then compounds 4, 1 and 3 (each within the scatter of the next, the first and the last beyond it).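

Among the compounds shown here, compound 2 and compound 4 are the first pair to differ in this one place alone, and in this assay the swap of 3,4-dichlorophenyl for (2-bromophenyl)amino on a carbonyl carbon gives a 2.2-fold higher number from compound 2 to compound 4 (0.34 log units; beyond the scatter). The step is modest, and it points towards lower toxicity in this test. Nothing measured here bears on why the number moves.

Going by these compounds, the swap brings in the amino link and changes the halogens on the ring together, so their separate shares remain open. On these data alone, how a plain phenylamino group or a simple amine on the carbonyl would read is also open.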